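The source may hold more compounds than are shown below. What is called first, only, known or untested is meant among the compounds shown, and "the series" means these compounds.

Measured so far, each in an ADME assay (liver) for metabolic stability, with Liver microsome (Homo sapiens) as the target, using microsomes; on this read-out lower numbers stand for a shorter-lived compound and higher numbers for a longer-lived compound (values follow)

Compound 1 `Cc1ccc2c(-c3ccc(Cl)cc3)c([C@H](OC(C)(C)C)C(=O)O)c(C)nc2c1` gives 3.83 h
Compound 2 `Cc1ccc2c(-c3ccc4c(c3Cl)NCCO4)c([C@H](OC(C)(C)C)C(=O)O)c(C)nc2c1` gives 1.08 h

Compound 1 holds the higher of these two numbers. The difference from compound 2 lies beyond the usual scatter of repeated measurements. Among the measured compounds shown here, no pair of measured compounds differs in just one place, so no clean single-change comparison is available yet.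

Compound 3 `Cc1ccc2c(-c3cccc4cccnc34)c([C@H](OC(C)(C)C)C(=O)O)c(C)nc2c1` is still unmeasured. It keeps the core of compound 1 and changes one group, on an aromatic carbon opposite the ring nitrogen: quinolin-8-yl in place of 4-chlorophenyl (quinolin-8-yl in place of 4-chlorophenyl on an aromatic carbon).

With so little data, any forecast is tentative. For the measured compounds named here, compound 1 (3.83 h) is the higher of only two readings, and the one other reading, from compound 2 (1.08 h), sits lower, so a moderate fall seems more likely than a rise. The expected change is a 1.9-fold lower number from compound 1 to compound 3 (0.28 log units; within the scatter) in this assay as an estimate, and it may not clear the scatter by much. The estimated half-life of compound 3 is 2 h (range 0.7 h to 5.5 h).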

Compound 3, half-life: > 5 h
Compound 3 gave a limit, no number (the forecaster's own chance of this, stated with the estimate: 3%); middle value at least 2.5-fold (0.39 log units) from the limit.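

In this assay, compound 3 reads > 5 h, which is a limit of the assay and not a number. Swapping 4-chlorophenyl for quinolin-8-yl on this aromatic carbon, opposite the ring nitrogen, gives the first single-change reading at this place, an at least 1.3-fold higher number from compound 1 to compound 3 (0.11 log units; that floor lies within the scatter), so the two-ring group with its ring nitrogen is carried here with no loss of half-life, although the printed floor of that step stays within the scatter and a real gain is not yet established. Because the reading stops at the limit, the true size of the step cannot be read, and the top of the measurable range now marks one compound of those shown: the limit of > 5 h in this assay, at which 1 of the 3 values shown sits.

The compounds shown leave open whether the second ring or the ring nitrogen of quinolin-8-yl matters more for this result, a question that naphthalen-1-yl, a two-ring group of carbon only, would help to separate. They also leave open how far the half-life of compound 3 extends past the limit, which only a reading over a longer range could settle.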